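Replacing the triazole by an amide chain: compound 4

A few compounds are considered here, and "the series" means these few. Any claim that something is new, unique, unknown or untested is made for them only; others in the source may bear on it.

In an ADME assay on microsomes from liver (Mus musculus) for metabolic stability (a higher number here means that the compound lasts longer, a lower number that the compound disappears faster), compound 3 `CC(C)C(c1nnc[nH]1)c1ccc(-c2ccc3cccc(F)c3c2)[nH]c1=O` gives 0.213 h, the lower of the two plain numbers in hand. Compound 2 `CCC(CC)(c1nnc[nH]1)c1ccc(-c2ccc3cccc(F)c3c2)[nH]c1=O` gives 0.447 h, and the gap between these two lies beyond the usual scatter. Compound 1 `CCn1ncc2c(F)cc(-c3ccc(C(CC)(CC)c4nnc(C)[nH]4)c(=O)[nH]3)cc21` reports only a limit, > 3 h, which is the limit of > 3 h in this assay, at which 1 of the 3 values shown sits. Compound 4 `CC(C)NC(=O)CC(c1ccc(-c2ccc3cccc(F)c3c2)[nH]c1=O)C(C)C` differs from compound 3 in one place: (isopropylcarbamoyl)methyl in place of 4H-1,2,4-triazol-3-yl on a saturated chain carbon bound to an aromatic carbon and a saturated chain carbon. The 4H-1,2,4-triazol-3-yl leaves and (isopropylcarbamoyl)methyl enters on a saturated chain carbon bound to an aromatic carbon and a saturated chain carbon. Among the compounds with values here, no measured pair carries this exchange, so the size of the step in this assay is not anchored; a modest rise of the half-life, within or just beyond the scatter, is expected, a 1.4-fold higher number from compound 3 to compound 4 (0.15 log units; within the scatter). Compound 4 is estimated at 0.3 h, between 0.1 h and 0.9 h.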

Compound 4, half-life: < 0.0667 h
Compound 4: no number, only a limit; the forecaster's own chance of this, stated with the estimate: 5%; middle value at least 4.4-fold (0.65 log units) away from the limit.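

At the saturated chain carbon bound to an aromatic carbon and a saturated chain carbon, the group is not interchangeable in this assay: (isopropylcarbamoyl)methyl in place of 4H-1,2,4-triazol-3-yl gives an at least 3.1-fold lower number from compound 3 to compound 4 (0.50 log units; beyond the scatter) in this pair. This is the first single-place step in the series shown, and it has only a floor, since compound 4 carries a limit and not a number: the limit of < 0.0667 h in this assay, at which 1 of the 4 values shown sits.

Open, as far as these compounds go, is whether the drop follows the amide or the absence of the ring. A carboxylic acid or a primary amine on a shorter chain at this carbon would separate the two.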